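Replacing Ethoxy with Cyclohexylmethoxy on Compound 2

A few compounds are considered here, and "the series" means these few. Any claim that something is new, unique, unknown or untested is made for them only; others in the source may bear on it.

Compound 1 `CC1=CSC(OCC2CCCCC2)(c2ccccc2)c2noc(=O)n21`: 870 nM
Compound 2 `CCOC1(c2cccc(OC)c2)SC=C(C)n2c1noc2=O`: 38 nM

Going by the values given here, only two compounds have been measured so far. In a functional assay (Left cardiac atrium, Cavia porcellus), with a stated time of 30 min (a higher number here means that more compound is needed for the effect, a lower number that less compound is needed), compound 2 has the lower of the two numbers at 38 nM, and less of it is needed for the effect. Compound 1 gives 870 nM. The gap between the two numbers lies beyond the scatter.

Compound 3 `COc1cccc(C2(OCC3CCCCC3)SC=C(C)n3c2noc3=O)c1` has not yet been measured. It departs from compound 2 in one place: cyclohexyl in place of methyl on a saturated chain carbon bound to an oxygen on a saturated carbon. Read one bond further out, the same change is ethoxy to cyclohexylmethoxy.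

Among the compounds with values here, no two measured compounds differ in one place only, so the data give no direct size for this change. Within the data shown here, the only guide is compound 1, which also carries cyclohexylmethoxy and gives 870 nM, although it differs from compound 2 elsewhere as well. A higher number, beyond the scatter, is therefore expected in this assay, though this rests on thin evidence. The expected size of the change is a 4.7-fold higher number from compound 2 to compound 3 (0.68 log units; beyond the scatter). Compound 3 is estimated at 180 nM, with an expected range of 40 nM to 800 nM.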

Compound 3, half-maximal effective concentration: 650 nM
Compound 3: middle estimate off by 3.6-fold (0.56 log units), on the low side; low and high end bracket the measured number.
By their numbers in this assay, from the lowest: compound 2; then compounds 3 and 1 (each within the scatter of the next).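

With compound 3, the change from ethoxy to cyclohexylmethoxy now has a direct size in this assay: a 17-fold higher number from compound 2 to compound 3 (1.23 log units; beyond the scatter), so cyclohexyl in place of methyl at this place is a large step towards needing more compound for the effect. The second step shows that, with cyclohexylmethoxy present, methoxy in place of hydrogen on an aromatic carbon gives no readable difference: a 1.3-fold lower number from compound 1 to compound 3 (0.13 log units; within the scatter), and compound 1 and compound 3 cannot be told apart in this assay. No measurement at hand accounts for the size of either step.

The compounds shown leave open whether the higher number follows from the cyclohexyl ring itself or from any group longer than ethoxy, a question that a straight butoxy chain or a benzyloxy group in place of ethoxy would address. They also leave open whether methoxy in place of hydrogen on an aromatic carbon would be equally without readable effect with ethoxy in place of cyclohexylmethoxy, since only the cyclohexylmethoxy pair gives that comparison.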